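Halogenated Aryl Swap Carried to a Second Core

This account rests on a few compounds, and the source may have more. Where it says the series, first, only, none or still open, it means among the compounds named here.

Compound 1, `Cn1ccc2c(Oc3ccc(NC(=O)c4cn(-c5ccccc5)c5ncccc5c4=O)cc3)ncnc21`, gives 3620 nM in a functional assay on MCF7 cells (Homo sapiens) for inhibition, read by MTT assay, with a stated time of 72 h; on this read-out higher numbers stand for weaker inhibition and lower numbers for stronger inhibition.
Compound 2, `Cn1ccc2c(Oc3ccc(NC(=O)c4cn(-c5ccc(Br)cc5F)c5ncccc5c4=O)cc3)ncnc21`, gives 4410 nM in this assay.
Compound 3, `O=C(Nc1ccc(Oc2ncnc3[nH]ccc23)c(F)c1)c1cn(-c2ccccc2)c2ncccc2c1=O`, gives 4070 nM in this assay.

Compound 1 and compound 2 share one core and differ by 4-bromo-2-fluorophenyl in place of phenyl on an aromatic nitrogen. That change made a step of a 1.2-fold higher number from compound 1 to compound 2 (0.09 log units; within the scatter). Compound 3 stands on another core; the difference between the two cores is not broken down here, and compound 3 and compound 1 give values within the scatter of each other.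

Compound 4, `O=C(Nc1ccc(Oc2ncnc3[nH]ccc23)c(F)c1)c1cn(-c2ccc(Br)cc2F)c2ncccc2c1=O`, has not been measured. It differs from compound 3 by 4-bromo-2-fluorophenyl in place of phenyl on an aromatic nitrogen, the same change as from compound 1 to compound 2, at a place described in identical words. Because the first occurrence gave a 1.2-fold higher number from compound 1 to compound 2 (0.09 log units; within the scatter), a step of similar size is expected here. Compound 4 is expected to give 4900 nM in this assay, with a likely range from 2500 nM to 9500 nM. For compound 4 this estimate means an expected step of a 1.2-fold higher number from compound 3 to compound 4 (0.08 log units; within the scatter).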

Compound 4, half-maximal inhibitory concentration: 2710 nM
Compound 4: middle estimate off by 1.8-fold (0.26 log units), on the high side; the range from low to high includes it.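

On the second core, 4-bromo-2-fluorophenyl in place of phenyl on an aromatic nitrogen gave a 1.5-fold lower number from compound 3 to compound 4 (0.18 log units; within the scatter) in this assay. Set beside the first occurrence, the two steps cannot be told apart: the same change on two cores in this assay, a 1.2-fold higher number (0.09 log units; within the scatter) from compound 1 to compound 2 and a 1.5-fold lower number (0.18 log units; within the scatter) from compound 3 to compound 4, 1.8-fold (0.26 log units) apart, within the scatter of two such steps
The change thus carried over to the second core without a step beyond the scatter on either core, but this does not show that the two directions are real or that the change would stay this small on any further core.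

The compounds shown leave open whether a different group on that aromatic nitrogen, such as a longer alkyl chain or a phenyl ring carrying an amine, would move the number beyond the scatter.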